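Fluoropyrimidine replacing the carbamate on the piperidine nitrogen

The compounds below may be only part of what the source reports. "The series", "measured", "known", "first", "only" and "open" are said of these compounds alone.

Measured compounds:
Compound 1 `CS(=O)(=O)c1ccc2c(c1)CCN2c1ncnc2c(C3CCN(c4ncccn4)CC3)coc12` – 512 nM
Compound 2 `CC(O)c1cnc(N2CCC(c3coc4c(N5CCc6cc(S(C)(=O)=O)ccc65)ncnc34)CC2)nc1` – 586 nM
Compound 3 `CC(C)(C)OC(=O)N1CCC(c2coc3c(N4CCc5cc(S(C)(=O)=O)ccc54)ncnc23)CC1` – 53 nM

In a functional assay on cells for agonist activity at Glucose-dependent insulinotropic receptor (Homo sapiens), read by a luciferase reporter, with a stated time of 4 h (a higher number here means that more compound is needed for the effect, a lower number that less compound is needed), compound 3 gives the lowest of the three numbers. Its nearest neighbour is compound 1, which in this assay gives 512 nM, and the step of a 9.7-fold lower number from compound 1 to compound 3 (0.98 log units; beyond the scatter) lies beyond the scatter. The step of an 11-fold lower number from compound 2 to compound 3 (1.04 log units; beyond the scatter) is of the same kind and even somewhat larger. Compound 1 and compound 2 sit close together, as a 1.1-fold higher number from compound 1 to compound 2 (0.06 log units; within the scatter) shows.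

Compound 4 `CS(=O)(=O)c1ccc2c(c1)CCN2c1ncnc2c(C3CCN(c4ncc(F)cn4)CC3)coc12` is not yet measured. Its difference from compound 3 is 5-fluoropyrimidin-2-yl in place of tert-butoxycarbonyl on an amine nitrogen in a ring. This reverses the direction of the two steps that led to compound 3: in both a 9.7-fold lower number from compound 1 to compound 3 (0.98 log units; beyond the scatter) and an 11-fold lower number from compound 2 to compound 3 (1.04 log units; beyond the scatter) a pyrimidin-2-yl group, bare or bearing 1-hydroxyethyl, was exchanged for tert-butoxycarbonyl and the number fell. Since compound 4 carries a pyrimidinyl group again, the step is expected to run the other way, with a rise in this assay of about the size seen before, so the expected step is a 9.4-fold higher number from compound 3 to compound 4 (0.97 log units; beyond the scatter). Compound 4 is therefore estimated at 500 nM in this assay, within a range of 200 nM to 1500 nM.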

Compound 4, half-maximal effective concentration: 201 nM
Compound 4: the middle estimate sits 2.5-fold (0.40 log units) above what was measured; the measured number falls inside the stated range.
By their numbers in this assay, from the lowest: compound 3; then compound 4; then compounds 1 and 2 (each within the scatter of the next).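

In this assay the 5-fluoropyrimidin-2-yl group shows that a pyrimidine on the amine nitrogen in the ring need not cost as much as compounds 1 and 2 suggested, although tert-butoxycarbonyl still gives the lower number (a 3.8-fold higher number from compound 3 to compound 4 (0.58 log units; beyond the scatter)). The new point lies on the pyrimidine itself: the aromatic carbon that looked insensitive when 1-hydroxyethyl replaced hydrogen (a 1.1-fold higher number from compound 1 to compound 2 (0.06 log units; within the scatter)) now turns out to affect the number, since fluoro in place of hydrogen gives a step beyond the scatter (a 2.5-fold lower number from compound 1 to compound 4 (0.41 log units; beyond the scatter)), and fluoro in place of 1-hydroxyethyl gives another (a 2.9-fold lower number from compound 2 to compound 4 (0.46 log units; beyond the scatter)). Nothing available here accounts for these steps.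

The compounds shown leave open whether another small group on that aromatic carbon, such as chloro, methyl or nitrile, would lower the number further and bring a pyrimidine compound level with compound 3. They also leave open whether an amine or a methoxy group there would follow fluoro or 1-hydroxyethyl, and whether other carbamates on the ring nitrogen would match tert-butoxycarbonyl.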